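Cyclohexyl in Place of Methyl on the Acyl Group

The source may hold more compounds than are shown below. What is called first, only, known or untested is meant among the compounds shown, and "the series" means these compounds.

Measured so far:
compound 1, `Cc1[nH]nc(N)c1-c1cc(C(F)(F)F)cc(C(F)(F)F)c1`, > 100000 nM
compound 2, `CC(=O)n1nc(C)c(-c2ccc(Cl)c(Cl)c2)c1N`, 8400 nM

Compound 1 `Cc1[nH]nc(N)c1-c1cc(C(F)(F)F)cc(C(F)(F)F)c1` was tested in an assay on Sf9 cells for inhibition of mitogen-activated protein kinase kinase kinase 14 (Homo sapiens), read by ADP-Glo, with a stated time of 60 min; a higher number here means a weaker inhibitor, a lower number a stronger inhibitor; for compound 1 the result > 100000 nM is a limit of the assay and not a number (the limit of > 100000 nM in this assay, at which 1 of the 2 values shown sits). Going by the values given here, compound 2 `CC(=O)n1nc(C)c(-c2ccc(Cl)c(Cl)c2)c1N` gives 8400 nM in this assay, the only number among the values shown. Compound 3 `Cc1nn(C(=O)C2CCCCC2)c(N)c1-c1ccc(Cl)c(Cl)c1` has not yet been measured. It differs from compound 2 in one place: cyclohexyl in place of methyl on a carbonyl carbon. Among the compounds with values here, no measured step between two compounds differing in one place exists here, so the data give no measured size for such a change. The step is expected to be modest, in either direction, and not clearly beyond the usual scatter. Compound 3 is therefore estimated at 6000 nM, between 1500 nM and 30000 nM. That estimate means an expected step of a 1.4-fold lower number from compound 2 to compound 3 (0.15 log units; within the scatter).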

Compound 3, half-maximal inhibitory concentration: 3300 nM
Compound 3: the middle estimate sits 1.8-fold (0.26 log units) above what was measured; the range from low to high includes it.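

In this assay, the carbonyl carbon on the aromatic nitrogen accepts a far larger group than methyl: cyclohexyl in place of methyl gives a 2.5-fold lower number from compound 2 to compound 3 (0.41 log units; beyond the scatter). Going by these compounds alone, this is the first measured size for any change at this position, and it shows that going from a single carbon to a six-membered ring of carbon does not cost activity here but brings a modest gain. The data shown offer no measured property that would explain this step.

As far as these compounds go, it remains open whether the ring itself matters or whether a longer chain such as n-butyl, or a phenyl ring, would serve as well on this carbonyl carbon. From the compounds shown here alone, it is also open how an amine or a carboxylic acid on the cyclohexyl would change the number, and whether the step would hold with a different aryl group on the shared core.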